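The source may hold more compounds than are shown below. What is called first, only, known or untested is meant among the compounds shown, and "the series" means these compounds.

In a functional assay on HCT-116 cells (Homo sapiens) for inhibition, read by CCK-8 assay, with a stated time of 48 h (on this read-out higher numbers stand for weaker inhibition and lower numbers for stronger inhibition), compound 1 `COc1cc(-c2ccnc3cc(-c4c[nH]c5ccccc45)nn23)cc(OC)c1OC` gives 35 nM, compound 2 `COc1cc(-c2ccnc3cc(-c4ccc(Cl)cc4)nn23)cc(OC)c1OC` gives 3340 nM and compound 3 `COc1cc(-c2ccnc3cc(-c4ccc(C(F)(F)F)cc4)nn23)cc(OC)c1OC` gives 1860 nM. Compound 3 therefore stands with compound 2 and far from compound 1. The gap between those two phenyl compounds is small, with a 1.8-fold lower number from compound 2 to compound 3 (0.25 log units; within the scatter).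

Compound 4 `COc1cc(-c2ccnc3cc(-c4cn(C)c5ccccc45)nn23)cc(OC)c1OC` makes one change to compound 3: 1-methyl-1H-indol-3-yl in place of 4-(trifluoromethyl)phenyl on an aromatic carbon. The most relevant steps are the large ones that replaced 1H-indol-3-yl, with a 53-fold higher number from compound 1 to compound 3 (1.73 log units; beyond the scatter) and a 95-fold higher number from compound 1 to compound 2 (1.98 log units; beyond the scatter). Among the measured compounds shown here, compound 4 restores the indole, but no measured compound carries its methyl group, so a large step to a lower number is expected, perhaps short of the full gap. The expected change is a 16-fold lower number from compound 3 to compound 4 (1.19 log units; beyond the scatter). The estimate for compound 4 is 120 nM, within a range of 25 nM to 600 nM.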

Compound 4, half-maximal inhibitory concentration: 762 nM
Estimate against measurement, compound 4: 6.4-fold (0.80 log units) below; measured number outside the range, above it.
By their numbers in this assay, from the lowest: compound 1; then compound 4; then compounds 3 and 2 (each within the scatter of the next).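

Restoring 1-methyl-1H-indol-3-yl at this position recovers only part of the lost inhibition: it beats the two phenyl groups, with a 2.4-fold lower number from compound 3 to compound 4 (0.39 log units; beyond the scatter) and a 4.4-fold lower number from compound 2 to compound 4 (0.64 log units; beyond the scatter), but both gains are modest. The hydrogen on the indole nitrogen turns out to matter as much as the ring itself, since methyl in its place gives a 22-fold higher number from compound 1 to compound 4 (1.34 log units; beyond the scatter). No measurement here explains why this hydrogen matters.

Open, going by these compounds, is how an ethyl or acetyl group on that nitrogen would compare. Also open, on these data alone, is whether a phenyl carrying an amine or hydroxyl could match the unsubstituted indole.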